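Open-Chain Amine in Place of a Pyrrolidine Ring

The source may hold more compounds than are shown below. What is called first, only, known or untested is meant among the compounds shown, and "the series" means these compounds.

Compound 1 `COc1c(N2CC[C@@H](CO)C2)c(F)cc2c(=O)c(C(=O)O)cn(Cc3ccc(-c4ccccc4)cc3)c12` was tested in an assay on isolated protein for inhibition of DNA topoisomerase 1 (Homo sapiens), with a stated time of 15 min; on this read-out lower numbers stand for stronger inhibition and higher numbers for weaker inhibition. In this assay compound 1 gives only > 200000 nM, which is a limit of the assay and not a measured number (the limit of > 200000 nM in this assay, at which 1 of the 2 values shown sits). Compound 2 `NCCNc1cc2c(cc1F)c(=O)c(C(=O)O)cn2Cc1ccc(-c2ccccc2)cc1`, which carries a related open-chain amine on the shared core but no methoxy group, gives 72800 nM in this assay. Compound 3 `CNCCNc1c(F)cc2c(=O)c(C(=O)O)cn(Cc3ccc(-c4ccccc4)cc3)c2c1OC` differs from compound 1 in one place: (2-(methylamino)ethyl)amino in place of 3-(hydroxymethyl)pyrrolidin-1-yl on an aromatic carbon. Among the compounds with values here, no measured pair shows this exact change. Since compound 2 gives 72800 nM in this assay, the open-chain amine is expected to bring compound 3 into the measurable range, with the step from compound 1 to compound 3 estimated as an at least 2.0-fold lower number from compound 1 to compound 3 (0.30 log units; that floor lies within the scatter). Compound 3 is therefore expected to give about 100000 nM in this assay, within a range from 30000 nM to 300000 nM.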

Compound 3, half-maximal inhibitory concentration: > 200000 nM
Compound 3 gave a limit, no number; the forecaster's own chance of this, stated with the estimate: 35%; at least 2.0-fold (0.30 log units) between middle value and limit.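

Within the data shown here, compound 1 and compound 3 both give only a limit of the assay in this assay, not a number, so no step between them can be read: the limit of > 200000 nM in this assay, at which 2 of the 3 values shown sit. From the compounds shown here alone, whether (2-(methylamino)ethyl)amino in place of 3-(hydroxymethyl)pyrrolidin-1-yl changes inhibition at all remains open.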